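A few compounds are considered here, and "the series" means these few. Any claim that something is new, unique, unknown or untested is made for them only; others in the source may bear on it.

Compound 3 `CCN(CC)c1ccc2cc(C(=O)c3ccc(N4CCN(C(=O)CN5CCN(Cc6ccc(F)c(F)c6)CC5)CC4)cc3)oc2c1` is one of three analogues built on a shared core in which a piperazine nitrogen carries a varied substituent. In a functional assay on SGC-7901 cells (Homo sapiens) for cytotoxicity, read by MTT assay, with a stated time of 48 h (a higher number here means a weaker inhibitor, a lower number a stronger inhibitor), compound 3 gives 1780 nM. Compound 1 `CCN(CC)c1ccc2cc(C(=O)c3ccc(N4CCN(C(=O)CN5CCN(C(=O)CCl)CC5)CC4)cc3)oc2c1` gives 1630 nM in this assay, and the two sit together within the scatter, as the step of a 1.1-fold higher number from compound 1 to compound 3 (0.04 log units; within the scatter) shows. Compound 2 `CCN(CC)c1ccc2cc(C(=O)c3ccc(N4CCN(C(=O)CN5CCN(S(=O)(=O)c6ccc(C#N)cc6)CC5)CC4)cc3)oc2c1` is reported in this assay only as a limit, > 40000 nM, (the limit of > 40000 nM in this assay, at which 1 of the 3 values shown sits). The step of an at least 22-fold lower number from compound 2 to compound 3 (1.35 log units; beyond the scatter) is large. Compound 4 `CCOC(=O)CN1CCN(CC(=O)N2CCN(c3ccc(C(=O)c4cc5ccc(N(CC)CC)cc5o4)cc3)CC2)CC1` differs from compound 3 by ethoxycarbonyl in place of 3,4-difluorophenyl on a saturated chain carbon bound to an amine nitrogen in a ring. Within the data shown here, of the measured steps, the one from compound 1 to compound 3 is the closest guide, as it swaps one small non-aromatic group on that ring nitrogen for the difluorobenzyl group without moving the number beyond the scatter, whereas the sulfonyl group of compound 2 lies far off. The expected step of a 1.7-fold higher number from compound 3 to compound 4 (0.23 log units; within the scatter) is therefore modest, leaning toward a higher number. Compound 4 is accordingly estimated at 3000 nM, with a range from 1000 nM to 12000 nM.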

Compound 4, half-maximal inhibitory concentration: > 40000 nM
Compound 4 was reported as a limit (the forecaster's own chance of this, stated with the estimate: 10%); middle value at least 13-fold (1.12 log units) away from the limit.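

Ethoxycarbonyl in place of 3,4-difluorophenyl gives an at least 22-fold higher number from compound 3 to compound 4 (1.35 log units; beyond the scatter), and (ethoxycarbonyl)methyl in place of (chloromethyl)carbonyl gives an at least 24-fold higher number from compound 1 to compound 4 (1.38 log units; beyond the scatter), so a large rise in the number on this ring nitrogen no longer belongs to the (4-cyanophenyl)sulfonyl group of compound 2 alone. Compound 1 carries no ring on this nitrogen and still stands within the scatter of compound 3, so the loss of the aromatic ring does not by itself account for the result with compound 4. Compound 4 is reported only as a limit, and its step to compound 2 cannot be read: the limit of > 40000 nM in this assay, at which 2 of the 4 values shown sit.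

On these data alone, how far compound 4 lies beyond that limit stays unknown. The compounds shown leave open whether a carboxylic acid or an amide in place of the ethyl ester would bring the number back towards that of compound 3.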